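This account rests on a few compounds, and the source may have more. Where it says the series, first, only, none or still open, it means among the compounds named here.

In a functional assay on HeLa cells (Homo sapiens) for inhibition, read by MTT assay, with a stated time of 48 h (on this read-out lower numbers stand for stronger inhibition and higher numbers for weaker inhibition), compound 1 `O=C(/C=C/c1coc2cc(O)ccc2c1=O)NCc1ccccc1` gives > 100000 nM, which is a limit of the assay and not a number. For the measured compounds named here, compound 2 `Cc1ccccc1NC(=O)/C=C/c1coc2cc(O)ccc2c1=O` gives 8670 nM, the only actual number so far. Compound 3 `Cc1ccc(CNC(=O)/C=C/c2coc3cc(O)ccc3c2=O)cc1` differs from it by 4-methylbenzyl in place of 2-methylphenyl on an amide-type nitrogen. Going by the values given here, the one measured step that bears on this change is an at least 11-fold lower number from compound 1 to compound 2 (1.06 log units; beyond the scatter), a large step beyond the scatter, with 2-methylphenyl in place of benzyl on an amide-type nitrogen. Compound 3 again has a benzyl-type group, so that step is expected to be largely reversed. For compound 3 the expected change is a 5.8-fold higher number from compound 2 to compound 3 (0.76 log units; beyond the scatter), toward higher numbers in this assay. The estimated value for compound 3 is 50000 nM, within an expected range of 15000 nM to 150000 nM.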

Compound 3, half-maximal inhibitory concentration: > 100000 nM
Compound 3: no number, only a limit (the forecaster's own chance of this, stated with the estimate: 50%); middle value at least 2.0-fold (0.30 log units) away from the limit.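

For the compounds shown here, putting 4-methylbenzyl in place of 2-methylphenyl on the amide-type nitrogen gives an at least 11-fold higher number from compound 2 to compound 3 (1.06 log units; beyond the scatter), so a methyl on the benzyl group does not bring back a measurable number, and compound 2 remains the only compound with one. Compound 1 and compound 3 both end at a limit, and the step between them cannot be read: the limit of > 100000 nM in this assay, at which 2 of the 3 values shown sit.

Going by these compounds, whether a phenyl group carrying an amine or a carboxylic acid in place of the methyl of compound 2 would hold or lower the number stays open.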